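A methoxy group added, and the expected effect on cytotoxicity

This account rests on a few compounds, and the source may have more. Where it says the series, first, only, none or still open, it means among the compounds named here.

Measured compounds:
compound 1, `O=c1oc2ccccc2cc1-c1cn2nc(-c3c([O-])[o+]nn3-c3ccc(Cl)cc3)sc2n1`: > 80 ug/mL
compound 2, `O=c1oc2ccc(Cl)cc2cc1-c1cn2nc(-c3c([O-])[o+]nn3-c3ccccc3)sc2n1`: > 80 ug/mL
compound 3, `COc1ccc(-n2n[o+]c([O-])c2-c2nn3cc(-c4cc5ccccc5oc4=O)nc3s2)cc1`: > 70 ug/mL

Three compounds on a shared core were tested in a functional assay on HT-29 cells (Homo sapiens) for cytotoxicity, read by sulforhodamine B assay; on this read-out higher numbers stand for lower toxicity in this test and lower numbers for higher toxicity in this test. Compound 1 gives > 80 ug/mL, which is a limit of the assay rather than a number. Compound 2 likewise gives > 80 ug/mL, again a limit. Compound 3 gives > 70 ug/mL, also a limit. The step that the two limits leave unreadable from compound 1 to compound 3 therefore cannot be read in size.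

Compound 4, `COc1ccc(-n2n[o+]c([O-])c2-c2nn3cc(-c4cc5cc(Cl)ccc5oc4=O)nc3s2)cc1`, has not yet been measured. It differs from compound 2 by methoxy in place of hydrogen on an aromatic carbon. Because all three measured values sit at limits, as shown by the limit of > 70 ug/mL in this assay, at which 1 of the 3 values shown sits, and (the limit of > 80 ug/mL in this assay, at which 2 of the 3 values shown sit), no measured step gives a readable size for a methoxy change on this core. Compound 4 is therefore expected to remain at the limit as well, with the step of a number no higher from compound 2 to compound 4 (the limit leaves the size open) expected to be none beyond the scatter. The estimate for compound 4 in this assay is 80 ug/mL, within 40 ug/mL to 160 ug/mL.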

Compound 4, concentration lethal to 50% of the cells: > 70 ug/mL
Compound 4: no number, only a limit; the forecaster's own chance of this, stated with the estimate: 85%; the middle value is on the limit's open side.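

Compound 4 also sits at a limit, so neither the step from compound 2 to compound 4 nor the step from compound 3 to compound 4 can be read in size. The compounds shown leave open whether methoxy or chloro changes the result in this assay on the shared core.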